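Ethyl capping of a ring hydroxy in a diarylpropane series

A few compounds are considered here, and "the series" means these few. Any claim that something is new, unique, unknown or untested is made for them only; others in the source may bear on it.

Measured so far:
compound 1, `CCC(c1ccc(O)c(O)c1)c1ccc(O)c(OC)c1`, 97%
compound 2, `CCC(c1ccc(O)c(OC)c1)c1cccc(O)c1O`, 96%

Both measured compounds were run in a functional assay for inhibition, with a stated time of 36 h, tested at 100 ug/mL; a higher number here means more inhibition at the concentration tested (going by the name of the read-out), a lower number less inhibition. Compound 1 gives 97%, and compound 2 gives 96%. Compound 2 carries the lower of the two numbers, but the gap to compound 1 lies within the scatter, so the two cannot be told apart on these data. Among the compounds with values here, no pair of measured compounds differs in a single place, so no step size is yet known for any structural change.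

Compound 3, `CCOc1cccc(C(CC)c2ccc(O)c(OC)c2)c1O`, is unmeasured. It differs from compound 2 by ethyl in place of hydrogen on an oxygen on an aromatic ring. Within the data shown here, no measured pair shows what ethyl in place of hydrogen on an oxygen on an aromatic ring does here, so the direction of the step is open; a downward step is expected as the more likely outcome, of the size a number 16 percentage points lower from compound 2 to compound 3 (beyond the scatter), with room for no change beyond the scatter. Compound 3 is therefore estimated at 80% in this assay, within a range of 45% to 98%.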

Compound 3, a percentage reported as inhibition, at one concentration (the size of the read-out at that concentration, not a potency): 96%
The estimate for compound 3 lay 16 percentage points below the measured number; low and high end bracket the measured number.
By their numbers in this assay, from the lowest: compounds 2, 3 and 1 (each within the scatter of the next).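

Ethyl in place of hydrogen on an oxygen on an aromatic ring, hydroxy to ethoxy, gives no change at the digits printed from compound 2 to compound 3 (within the scatter) in this assay, the first single-place step that can be read in this series. The number therefore stays level with ethyl on this oxygen, and the free hydroxy hydrogen of compound 2 is not needed for the inhibition seen at the concentration tested: compound 3 gives 96%. Nothing at hand bears on why the read-out holds after this change.

The read-out is taken at one concentration and is not a potency, so any difference between compound 2 and compound 3 that would appear only at lower concentrations remains unresolved. Also open, as far as these compounds go, is whether the number stays level after other changes: a longer chain such as butyl, a group ending in a carboxylic acid or an amine, or the same ethyl group on another ring hydroxy could each give a different number in this assay.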